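The source may report more compounds than this note shows. Statements on the series, on what has been measured and on what is new or still open speak of the compounds shown alone.

Three related compounds have been measured in a functional assay on the whole organism for agonist activity, with Mus musculus as the target; on this read-out higher numbers stand for an effect only at larger amounts of compound and lower numbers for an effect already at smaller amounts. Compound 1 (`CC(=O)N(C)CC#CCn1cncc1C`) gives 5.4 mg/kg, compound 2 (`CCOC(=O)N(C)CC#CCn1cncc1C`) gives 97 mg/kg, and compound 3 (`CN(C)C(=O)N(C)CC#CCn1ccnc1`) gives 11.8 mg/kg. Compound 3 therefore holds the middle place, with the second highest number of the three, and it lies closer to compound 1 than to compound 2.

Compound 4 (`Cc1cncn1CC#CCN(C)C(=O)N(C)C`) has not yet been measured. It differs from compound 3 by a single change, methyl in place of hydrogen on an aromatic carbon.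

Among the measured compounds shown here, the only measured step with a single change is an 18-fold higher number from compound 1 to compound 2 (1.25 log units; beyond the scatter). That large step swaps ethoxy for methyl on a carbonyl carbon, so it shows how far one change can move the number in this assay, but it does not involve the new methyl. For the measured compounds named here, compounds 1 and 2 both carry this ring methyl, yet they also differ from compound 3 in the group on the carbonyl carbon, so no measured pair isolates its effect.

With no evidence for either direction, the expected step is a 1.0-fold higher number from compound 3 to compound 4 (0.01 log units; within the scatter), which means no clear change, though the uncertainty is wide. For compound 4 the estimated value is 12 mg/kg, with an expected range from 4 mg/kg to 40 mg/kg.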

Compound 4, dose for half-maximal effect: 45.2 mg/kg
Beside the measured number, compound 4's estimate is 3.8-fold (0.58 log units) below it; the whole stated range lies below it.
By their numbers in this assay, from the lowest: compound 1; then compound 3; then compound 4; then compound 2.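

In this assay methyl in place of hydrogen on an aromatic carbon, next to the ring atom that bears a large group, can now be read as a single change, and it gives a 3.8-fold higher number from compound 3 to compound 4 (0.58 log units; beyond the scatter) so that more compound is needed for the same effect. With this ring methyl present in all three compounds, the group on the carbonyl carbon can also be compared: dimethylamino in place of methyl gives an 8.4-fold higher number from compound 1 to compound 4 (0.92 log units; beyond the scatter) and dimethylamino in place of ethoxy gives a 2.1-fold lower number from compound 2 to compound 4 (0.33 log units; beyond the scatter) which puts compound 4 in the middle of that set. Nothing in the data shown explains why the number rises with this methyl.

Among the compounds shown here, the methyl step is seen only with dimethylamino on the carbonyl carbon, so it remains open whether it would have the same size with methyl or ethoxy there. As far as these compounds go, it is also open how the number would respond to an ethyl group or a chlorine atom on this ring carbon in place of the methyl.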